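Swapping the aryl group on a hydrazone carboxamide core

This account rests on a few compounds, and the source may have more. Where it says the series, first, only, none or still open, it means among the compounds named here.

Compound 1 `Cc1cc2c(cc1C)C(Cl)=C(/C=N\NC(=O)C1=C(Cl)c3cc(C)c(C)cc3CCC1)CCC2` gives in a functional assay on HeLa cells (Homo sapiens) for inhibition, read by sulforhodamine B assay, with a stated time of 48 h (a higher number here means a weaker inhibitor of growth, a lower number a stronger inhibitor of growth), a limit rather than a number: compound 1 shows > 100000 nM.
Compound 2 `O=C(N/N=C/C1=C(Cl)c2ccccc2CCC1)c1ccccc1` also reaches only a limit in this assay: compound 2 shows > 100000 nM.
Compound 3 `Cc1ccc(C(=O)N/N=C/C2=C(Cl)c3ccccc3CCC2)cc1` gives a number in this assay: compound 3 shows 300 nM.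

Within the data shown here, compound 3 therefore stands alone as the only compound with a measured number; the other two sit at the limit (the limit of > 100000 nM in this assay, at which 2 of the 3 values shown sit). Among the measured compounds shown here, the one step between measured compounds that can be read is an at least 330-fold lower number from compound 2 to compound 3 (2.52 log units; beyond the scatter), where methyl in place of hydrogen on an aromatic carbon turns a limit into a number.

Compound 4 `O=C(N/N=C/C1=C(Cl)c2ccccc2CCC1)c1cccc(Cl)c1` differs from compound 3 in that ring only: 3-chlorophenyl in place of 4-methylphenyl on a carbonyl carbon. For the measured compounds named here, no measured step swaps one group on that ring for another, so the step from compound 2 to compound 3 bears on it only indirectly, by showing that a change on this ring can move the number a long way. The 3-chlorophenyl may hold part of what the 4-methylphenyl brought, or not.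

Compound 4 is estimated at 3000 nM, within 300 nM to 100000 nM, which means an expected step of a 10-fold higher number from compound 3 to compound 4 (1.00 log units; beyond the scatter).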

Compound 4, concentration for 50% growth inhibition: 19200 nM
Compound 4: middle estimate off by 6.4-fold (0.81 log units), on the low side, within the range that was stated.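

Compound 4 shows that on this ring, attached to the carbonyl carbon, the number depends on which group is present and not only on whether there is one: 3-chlorophenyl in place of 4-methylphenyl gives a 64-fold higher number from compound 3 to compound 4 (1.81 log units; beyond the scatter). Even so, the 4-methylphenyl of compound 3 is not the only ring that yields a measurable number, since the 3-chlorophenyl also gives an at least 5.2-fold lower number from compound 2 to compound 4 (0.71 log units; beyond the scatter). That second step can be stated only as a bound, because compound 2 sits at a limit of the assay and not at a number: the limit of > 100000 nM in this assay, at which 2 of the 4 values shown sit.

The swap changes both the kind of group and its place on the ring, so the compounds shown cannot say which of the two accounts for the gap; a 4-chlorophenyl or a 3-methylphenyl on the same core would separate them. From the compounds shown here alone, it also remains open whether a ring carrying a different kind of group, such as 4-methoxyphenyl or 4-aminophenyl, would give a number closer to that of compound 3 or fall back to the limit.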